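The source may hold more compounds than are shown below. What is called first, only, known or untested is meant among the compounds shown, and "the series" means these compounds.

Of the compounds shown here, three built on one shared core have been tested in a functional assay on MDA-MB-231 cells (Homo sapiens) for inhibition, read by MTT assay, with a stated time of 48 h; a higher number here means a weaker inhibitor, a lower number a stronger inhibitor. Compound 1 `Cn1c(/C=C2\SC(=O)N(CC(=O)N3CCCCC3)C2=O)nc2ccccc21` carries a methyl on an aromatic nitrogen and a piperidin-1-yl on a carbonyl carbon. In this assay compound 1 gives only a limit of the assay, > 50000 nM. Compound 2 `CC(C)n1c(/C=C2\SC(=O)N(CC(=O)N3CCCCC3)C2=O)nc2ccccc21` differs from compound 1 by isopropyl in place of methyl on an aromatic nitrogen. In this assay compound 2 also gives only a limit, > 50000 nM. The step that the two limits leave unreadable from compound 1 to compound 2 therefore cannot be sized. Compound 3 `CC1CN(C(=O)CN2C(=O)S/C(=C\c3nc4ccccc4n3C)C2=O)CC(C)O1` differs from compound 1 in its core by 2,6-dimethylmorpholin-4-yl in place of piperidin-1-yl on a carbonyl carbon. In this assay compound 3 likewise gives only a limit, > 50000 nM. Within the data shown here, the step that the two limits leave unreadable from compound 1 to compound 3 is unreadable for the same reason, since every value so far sits at the limit of > 50000 nM in this assay, at which 3 of the 3 values shown sit.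

Compound 4 `CC1CN(C(=O)CN2C(=O)S/C(=C\c3nc4ccccc4n3C(C)C)C2=O)CC(C)O1` has not yet been measured. It differs from compound 3 by isopropyl in place of methyl on an aromatic nitrogen. The place of this change is the same, word for word, as the place of the change from compound 1 to compound 2, so it is the same change, and its earlier instance gave a step that the two limits leave unreadable from compound 1 to compound 2. Its starting point is a compound whose value in this assay is only a limit.

On that footing compound 4 is expected in this assay to lie near 70000 nM, between 30000 nM and 200000 nM, most probably reported again as a limit. The expected step that the limit leaves unreadable from compound 3 to compound 4 is estimated to leave compound 4 at the limit as well.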

Compound 4, half-maximal inhibitory concentration: > 50000 nM
Compound 4 was reported as a limit; the forecaster's own chance of this, stated with the estimate: 85%; the middle value does not contradict the limit.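

In this assay compound 4 gives > 50000 nM as well, again only a limit, so the steps reaching it from compound 3 and from compound 2 cannot be read. The whole set now stands at one value: the limit of > 50000 nM in this assay, at which 4 of the 4 values shown sit. The compounds shown leave open whether either change alters inhibition in this assay at all, and how strong an inhibitor compound 1, compound 2, compound 3 or compound 4 is.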